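This account rests on a few compounds, and the source may have more. Where it says the series, first, only, none or still open, it means among the compounds named here.

Measured in a functional assay on MDA-MB-435 cells (Homo sapiens) for cytotoxicity, read by MTT assay, with a stated time of 72 h; on this read-out higher numbers stand for weaker inhibition and lower numbers for stronger inhibition:
- Compound 1 `CS(=O)(=O)Oc1c(C(=O)NCc2ccc(F)cc2)nc(Br)c2cccnc12`: > 20000 nM
- Compound 2 `N[C@H]1CC[C@H](Nc2c(C(=O)NCc3ccco3)nc(Br)c3cccnc23)CC1`: > 10000 nM
- Compound 3 `N[C@H]1CC[C@H](Nc2c(C(=O)NCc3ccc(Oc4ccccc4)cc3)nc(Br)c3cccnc23)CC1`: 4000 nM

Compound 1 stands at > 20000 nM, which is a limit of the test and not a true number. Compound 2 also gives only a limit, > 10000 nM. Going by the values given here, compound 3 gives the only true number of the three, 4000 nM.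

Compound 4 `Nc1ccc(Nc2c(C(=O)NCc3ccc(F)cc3)nc(Br)c3cccnc23)cc1` has not been measured yet. It keeps the core and amide of compound 1 but has (4-aminophenyl)amino in place of (methylsulfonyl)oxy on an aromatic carbon.

Among the compounds with values here, no measured pair shows this exact change. Compound 3 has a ring linked through nitrogen on that carbon and reaches 4000 nM, so some gain is expected. Compound 2 goes against this, as it has such a ring too yet gives only a limit.

In this assay, the expected step of an at least 6.6-fold lower number from compound 1 to compound 4 (0.82 log units; beyond the scatter) points towards stronger inhibition. Its size is loose, as it starts from a limit. For compound 4 the estimated value is 3000 nM, with an expected range from 500 nM to 15000 nM.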

Compound 4, half-maximal inhibitory concentration: 7000 nM
Compound 4: the middle estimate sits 2.3-fold (0.37 log units) below what was measured; measured number inside the range.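

In this assay, with the amide and the rest of the core unchanged, (4-aminophenyl)amino in place of (methylsulfonyl)oxy on this aromatic carbon gives an at least 2.8-fold lower number from compound 1 to compound 4 (0.45 log units; beyond the scatter). This is the first pair shown that differs in this one place, and it ties the change in the number directly to the group on this carbon, para to a bromo group. The true size of the step cannot be read, because compound 1 gives only a limit of the test and not a true starting number: the limit of > 20000 nM in this assay, at which 1 of the 4 values shown sits.

The compounds shown leave open whether the aromatic ring, the free amine on it or the nitrogen link to the core matters most. A plain phenylamino group, without that amine, or a morpholine ring on the same carbon could begin to separate these parts.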